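A few compounds are considered here, and "the series" means these few. Any claim that something is new, unique, unknown or untested is made for them only; others in the source may bear on it.

Measured so far in a functional assay on CCRF-CEM cells (Homo sapiens) for inhibition, read by cell counting, with a stated time of 3 days; a higher number here means a weaker inhibitor, a lower number a stronger inhibitor:
compound 1 `C=C(Br)C(=O)Nc1cccc(-c2cn3nc(-c4ccc(C)cc4)sc3n2)c1` gives 1700 nM 
compound 2 `C=C(Br)C(=O)Nc1cccc(-c2cn3nc(Cc4ccc(OC)cc4)sc3n2)c1` gives 2300 nM 

Compound 2 holds the highest of the two numbers; its nearest neighbour is compound 1, and the step of a 1.4-fold higher number from compound 1 to compound 2 (0.13 log units; within the scatter) lies within the scatter, so the two are not separable on these data.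

Compound 3 `C=C(Br)C(=O)Nc1cccc(-c2cn3nc(-c4ccccc4)sc3n2)c1` is the next point in the series. Change from compound 2: phenyl in place of 4-methoxybenzyl on an aromatic carbon 

Within the data shown here, the one measured step that bears on this position is a 1.4-fold higher number from compound 1 to compound 2 (0.13 log units; within the scatter), where a 4-methylphenyl directly on the ring was exchanged for 4-methoxybenzyl without a shift beyond the scatter. Compound 3 returns to a directly attached ring, as in compound 1, but without the methyl. Among the measured compounds shown here, with only that step for guidance, no change beyond the scatter is expected in this assay, leaning, if anything, toward the lower number of compound 1.

For compound 3 the expected step is a 1.3-fold lower number from compound 2 to compound 3 (0.11 log units; within the scatter). Compound 3 is therefore estimated at 1800 nM, with a range from 800 nM to 4000 nM.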

Compound 3, half-maximal inhibitory concentration: 960 nM
Beside the measured number, compound 3's estimate is 1.9-fold (0.27 log units) above it, and the stated range covers the measured number.
By their numbers in this assay, from the lowest: compounds 3, 1 and 2 (each within the scatter of the next, the first and the last beyond it).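

In this assay this position now shows a step beyond the scatter, a 2.4-fold lower number from compound 2 to compound 3 (0.38 log units; beyond the scatter), modest in size, for phenyl in place of 4-methoxybenzyl, whereas the earlier exchange, a 1.4-fold higher number from compound 1 to compound 2 (0.13 log units; within the scatter), stayed within it. With hydrogen in place of methyl on the directly attached ring, the step is a 1.8-fold lower number from compound 1 to compound 3 (0.25 log units; within the scatter), so compound 1 and compound 3 cannot be separated and the methyl has no readable effect here. No supporting data explain the difference between compound 2 and compound 3.

Because 4-methoxybenzyl and phenyl differ in both the methoxy group and the carbon link to the ring, the step does not show which of the two matters. As far as these compounds go, the effect of an amine or a carboxylic acid on the phenyl ring, or of a longer chain in its place, also remains open.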